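The source may hold more compounds than are shown below. What is called first, only, known or untested is meant among the compounds shown, and "the series" means these compounds.

Going by the values given here, in an ADME assay on L6 cells (Rattus norvegicus) for cytotoxicity (on this read-out higher numbers stand for weaker inhibition and lower numbers for stronger inhibition), compound 1 `CN1CCN(CCCC(=O)OC2CC3(N4CCCCC4)CC(c4ccccc4)C2C(c2ccccc2)C3)CC1` gives 22300 nM and stands highest of the two numbers so far, while compound 2 `CN1CCN(CCCC(=O)OC2CC3(N4CCCC4)CC(c4ccccc4)C2C(c2ccccc2)C3)CC1` gives 10200 nM on the same read-out. Compound 3 `CN1CCN(CCC(=O)OC2CC3(N4CCCCC4)CC(c4ccccc4)C2C(c2ccccc2)C3)CC1` is still unmeasured. The change from compound 1 to compound 3 is counted as 4-methylpiperazin-1-yl in place of (4-methylpiperazin-1-yl)methyl on a saturated chain carbon, two bonds along the chain from a carbonyl carbon and amounts to 4-methylpiperazin-1-yl in place of (4-methylpiperazin-1-yl)methyl on a saturated chain carbon, two bonds along the chain from a carbonyl carbon. Among the compounds with values here, the only measured step of a 2.2-fold lower number from compound 1 to compound 2 (0.34 log units; beyond the scatter) is modest and beyond the scatter, but it concerns pyrrolidin-1-yl in place of piperidin-1-yl on a saturated ring carbon, not this chain, so it offers a size and no direction. In this assay a step of that modest size or smaller is therefore expected, with no direction favoured. The estimated step of a 1.1-fold lower number from compound 1 to compound 3 (0.05 log units; within the scatter) is expected to stay within the scatter. Compound 3 is expected at 20000 nM with an estimated range from 9000 nM to 45000 nM on this read-out.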

Compound 3, half-maximal inhibitory concentration: 23500 nM
Estimate against measurement, compound 3: 1.2-fold (0.07 log units) below; measured number inside the range.
By their numbers in this assay, from the lowest: compound 2; then compounds 1 and 3 (each within the scatter of the next).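

Going from 3-(4-methylpiperazin-1-yl)propyl to 2-(4-methylpiperazin-1-yl)ethyl on the carbonyl gives a 1.1-fold higher number from compound 1 to compound 3 (0.02 log units; within the scatter) in this assay, the first reading of a change at this position. Going by these compounds alone, for these two chain lengths, the change on a saturated chain carbon, two bonds along the chain from a carbonyl carbon, stays within the scatter, whereas a 2.2-fold lower number from compound 1 to compound 2 (0.34 log units; beyond the scatter), at the saturated ring carbon, remains the only step beyond it. Nothing available bears on why the two chains read alike.

Open, as far as these compounds go, is whether a longer chain, or a morpholine or a carboxylic acid in place of the 4-methylpiperazin-1-yl group, would also stay within the scatter. Also open is whether the pyrrolidin-1-yl for piperidin-1-yl step carries over to the 2-(4-methylpiperazin-1-yl)ethyl chain; the compounds shown hold that change only on the 3-(4-methylpiperazin-1-yl)propyl chain.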